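The compounds below may be only part of what the source reports. "The series", "measured", "known", "first", "only" and "open" are said of these compounds alone.

For the measured compounds named here, compound 3 `COc1ccc(-c2cn3cc(C4=CCN(C(=O)C5CCCCC5)CC4)ccc3n2)cc1OC` gives 7310 nM in a functional assay on A549 cells (Homo sapiens) for antiproliferative activity, read by MTT assay, with a stated time of 48 h (on this read-out lower numbers stand for stronger inhibition and higher numbers for weaker inhibition), the highest of the three numbers so far. Compound 1 `COc1ccc(-c2cn3cc(C4=CCN(C(=O)c5ccccc5C(F)(F)F)CC4)ccc3n2)cc1OC` gives 2550 nM and compound 2 `COc1ccc(-c2cn3cc(C4=CCN(C(=O)c5cccs5)CC4)ccc3n2)cc1OC` gives 5200 nM. The measured steps were a 2.9-fold higher number from compound 1 to compound 3 (0.46 log units; beyond the scatter) and a 1.4-fold higher number from compound 2 to compound 3 (0.15 log units; within the scatter), each a change of the group on the carbonyl carbon. Compound 4 `COc1ccc(-c2cn3cc(C4=CCN(C(=O)C5CC5)CC4)ccc3n2)cc1OC` differs in that same place: cyclopropyl in place of cyclohexyl on a carbonyl carbon. Going by the values given here, no measured step swaps one ring of carbon only for a smaller one, so nothing observed bears directly on this change, and the nearest precedent, the step of a 1.4-fold higher number from compound 2 to compound 3 (0.15 log units; within the scatter), was small. The expected step of a 1.0-fold lower number from compound 3 to compound 4 (0.02 log units; within the scatter) is therefore none beyond the scatter. Compound 4 is estimated at 7000 nM, within 3000 nM to 17000 nM.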

Compound 4, half-maximal inhibitory concentration: 9140 nM
Compound 4: the middle estimate sits 1.3-fold (0.12 log units) below what was measured; measured number inside the range.
By their numbers in this assay, from the lowest: compound 1; then compounds 2, 3 and 4 (each within the scatter of the next).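

In this assay, cyclopropyl in place of cyclohexyl on the carbonyl carbon gives a 1.3-fold higher number from compound 3 to compound 4 (0.10 log units; within the scatter), so these two carbon-only rings cannot be told apart here despite their different sizes. Cyclopropyl in place of thiophen-2-yl gives a 1.8-fold higher number from compound 2 to compound 4 (0.24 log units; within the scatter), while cyclopropyl in place of 2-(trifluoromethyl)phenyl gives a 3.6-fold higher number from compound 1 to compound 4 (0.55 log units; beyond the scatter), the only one of these new steps beyond the scatter. Nothing measured here explains these results.

On these data alone, whether an unsubstituted phenyl group would match the 2-(trifluoromethyl)phenyl group remains open. So does the effect of an amine, a carboxylic acid or a longer open chain at this position.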